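This account rests on a few compounds, and the source may have more. Where it says the series, first, only, none or still open, it means among the compounds named here.

Measured so far in a functional assay on the whole organism (strain Swiss albino) with Mus musculus as the target, in the maximal electroshock model, with a stated time of 0.5 h; on this read-out higher numbers stand for an effect only at larger amounts of compound and lower numbers for an effect already at smaller amounts:
compound 1 `COc1cc(/C=N/NC(=O)Nc2cccc3ccccc23)cc(OC)c1OC` – 100 mg/kg
compound 2 `COc1cc(/C=N/NC(=O)Nc2cccc3ccccc23)ccc1O` – 300 mg/kg
compound 3 `O=C(N/N=C/c1ccc(O)cc1)Nc1cccc2ccccc12` – 100 mg/kg

Compound 3 reads level with compound 1 at the digits given, and together they show the lowest numbers of the three. The one shown step reaching compound 3 is a 3.0-fold lower number from compound 2 to compound 3 (0.48 log units; beyond the scatter), hydrogen in place of methoxy on an aromatic carbon, a modest step beyond the scatter. Between compound 1 and compound 3 no step is shown; their two values simply read the same.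

The next compound, compound 4 `CN(C)c1ccc(/C=N/NC(=O)Nc2cccc3ccccc23)cc1`, is not yet measured. Against compound 3 the change is dimethylamino in place of hydroxy on an aromatic carbon. No measured step exchanges one substituent for another on an aromatic carbon; the single step shown, a 3.0-fold lower number from compound 2 to compound 3 (0.48 log units; beyond the scatter), concerns loss of a methoxy and gives only an indirect guide for dimethylamino in place of hydroxy. Within the data shown here, with the three numbers lying in a narrow span and no step bearing directly on the change, the expectation in this assay is no step beyond the scatter, or at most a small one in either direction, so no change at the digits printed from compound 3 to compound 4 (within the scatter) is the expected outcome. Compound 4 is estimated at 100 mg/kg with a range of 30 mg/kg to 300 mg/kg, kept wide on both sides because a 3.0-fold lower number from compound 2 to compound 3 (0.48 log units; beyond the scatter) is modest and indirect.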

Compound 4, minimum effective dose: 100 mg/kg
Compound 4: middle estimate and measured number agree at the digits printed; the measured number falls inside the stated range.
By their numbers in this assay, from the lowest: compounds 1, 3 and 4 (each within the scatter of the next); then compound 2.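

In this assay, dimethylamino in place of hydroxy on an aromatic carbon, para to a large group, gives no change at the digits printed from compound 3 to compound 4 (within the scatter), and this is the only step shown that exchanges one substituent for another at this place. The exchange brings in 3 heavy atoms for 1 and 0 hydrogen-bond donors for 1, so across these two compounds neither the hydroxy group nor its hydrogen-bond donor is needed to keep the printed reading, and a group with more heavy atoms is accepted here without a step beyond the scatter. No measurement shown speaks to why the two compounds read alike.

Still open, as far as these compounds go, is whether this tolerance extends to a carboxylic acid, a nitrile, a morpholine or a longer chain such as diethylamino at the same place, any of which could show whether the reading moves beyond the scatter. Among these compounds, also open is whether dimethylamino would be tolerated equally with a methoxy group on the same ring, since the one step involving methoxy, a 3.0-fold lower number from compound 2 to compound 3 (0.48 log units; beyond the scatter), was read only with hydroxy present.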